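The source may hold more compounds than are shown below. What is called first, only, known or untested is meant among the compounds shown, and "the series" means these compounds.

Measured so far:
- compound 1, `Cc1nc(C(F)(F)F)ncc1C(=O)Nc1cc(C(F)(F)F)cc(C(F)(F)F)c1`: in an assay on Jurkat cells for activation of nuclear factor NF-kappa-B complex (Homo sapiens) (a higher number here means a weaker inhibitor, a lower number a stronger inhibitor), compound 1 gives only a limit, > 10000 nM.
- compound 2, `CCCc1nc(Cl)ncc1C(=O)Nc1cc(C(F)(F)F)cc(C(F)(F)F)c1`: in this assay compound 2 gives 500 nM.

Compound 2 holds the only actual number shown; the other value, that of compound 1, is a limit of the assay rather than a measurement, as noted in the limit of > 10000 nM in this assay, at which 1 of the 2 values shown sits. Among the measured compounds shown here, no pair of measured compounds differs in just one place, so no measured step exists to lean on.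

The next compound, compound 3, `Cc1nc(Cl)ncc1C(=O)Nc1cc(C(F)(F)F)cc(C(F)(F)F)c1`, differs from compound 2 by hydrogen in place of ethyl on a saturated chain carbon bound to an aromatic carbon, so the chain on the core becomes shorter. For the measured compounds named here, with nothing measured for such a change here, the expectation rests on the single number of compound 2. Compound 3 is expected to come out around 1500 nM, within a range of 500 nM to 5000 nM. That estimate corresponds to a step of a 3.0-fold higher number from compound 2 to compound 3 (0.48 log units; beyond the scatter), a modest weakening, though a result within the scatter would not be surprising.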

Compound 3, half-maximal inhibitory concentration: 50 nM
Compound 3: the middle estimate sits 30-fold (1.48 log units) above what was measured; the measured number lies below the stated range.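

On a saturated chain carbon bound to an aromatic carbon, chain length clearly matters: shortening propyl to methyl gives a 10-fold lower number from compound 2 to compound 3 (1.00 log units; beyond the scatter), so the shorter chain goes with the stronger inhibitor in this assay. A second place on the core matters as well, since chloro in place of trifluoromethyl on an aromatic carbon gives an at least 200-fold lower number from compound 1 to compound 3 (2.30 log units; beyond the scatter). The true size of that second step stays unknown, since compound 1 gives only a limit and not a number: the limit of > 10000 nM in this assay, at which 1 of the 3 values shown sits.

As far as these compounds go, two chain lengths cannot show a trend, so it remains open whether an ethyl chain would fall between methyl and propyl, or whether a lone hydrogen would do better still. From the compounds shown here alone, how a bromo or nitrile group would compare with chloro is also open.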